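The source may hold more compounds than are shown below. What is called first, only, known or untested is meant among the compounds shown, and "the series" means these compounds.

Measured compounds so far:
- compound 1, `CC(=O)CC/C=C(\C)CCC1=C(C)CCCC1(C)C`
- compound 2, `C=C1CCC[C@H]2[C@](C)(CC[C@]3(C)CC[C@@H]([C@@H](C)C(=O)O)OO3)[C@@H](C)CC[C@]12C`
- compound 3, `C=C1CCCC(C)(C)C1CC[C@@]1(C)CC[C@H]([C@@H](C)C(=O)O)OO1`

In a functional assay on SK-MEL-2 cells (Homo sapiens) for inhibition (a higher number here means a weaker inhibitor of growth, a lower number a stronger inhibitor of growth), compound 1 gives only a limit, > 15000 nM, which is the limit of > 15000 nM in this assay, at which 1 of the 3 values shown sits. Compound 2 also gives only a limit in this assay, > 5000 nM, namely (the limit of > 5000 nM in this assay, at which 1 of the 3 values shown sits). Compound 3 gives a measured number in this assay, 5060 nM. Within the data shown here, compound 2 therefore stands at a limit rather than at a known number, and the only numerical value among the three belongs to compound 3.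

Compound 4, `C=C1CCC[C@H]2[C@](C)(CC[C@]3(C)CC[C@H]([C@@H](C)C(=O)O)OO3)[C@@H](C)CC[C@]12C`, has not yet been measured. It differs from compound 2 in this way: the two compounds have the same atoms and bonds and differ only in configuration as drawn: 1 of 7 stereo elements differ; a stereocentre at a saturated ring carbon is drawn S in compound 2 and R in compound 4. Among the measured compounds shown here, no step between two measured compounds here shows how a change of configuration at a single centre of this kind plays out in this assay, so there is no measured size to lean on. The step from compound 2 to compound 4 is expected to be small, a step that the limit leaves unreadable from compound 2 to compound 4, with no clear direction beyond the scatter. Compound 4 is accordingly estimated at 7000 nM, with a plausible range from 2500 nM to 20000 nM, and a fair chance that the assay again reports only a limit.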

Compound 4, concentration for 50% growth inhibition: 2170 nM
The estimate for compound 4 lay 3.2-fold (0.51 log units) above the measured number; the whole stated range lies above it.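

Turning a single saturated ring carbon from S to R gives, in this assay, an at least 2.3-fold lower number from compound 2 to compound 4 (0.36 log units; beyond the scatter), the first sign among these compounds that configuration at this centre can shift growth inhibition. Compound 2 stands at a limit, > 5000 nM, so the step has a known minimum but no known full size. The shift can be assigned to this one centre, because nothing else separates the pair: the fact that compounds 2 and 4 differ only in the configuration as drawn

A single pair cannot tell whether the same change of configuration would give a step of similar size on the core of compound 3. It also leaves open how a methyl ester or a primary amide in place of the carboxylic acid would read in this assay.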